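A few compounds are considered here, and "the series" means these few. Any claim that something is new, unique, unknown or untested is made for them only; others in the source may bear on it.

Measured compounds:
Compound 1 `Cc1nc(N)c2c(-c3cccs3)cn([C@@H]3O[C@H](CO)[C@@H](O)[C@H]3O)c2n1`: in a functional assay on HeLa S3 cells (Homo sapiens) for antiproliferative activity, read by XTT assay, with a stated time of 72 h (on this read-out lower numbers stand for stronger inhibition and higher numbers for weaker inhibition), compound 1 gives > 20000 nM, which is a limit of the assay and not a number.
Compound 2 `Nc1nc2c(c(-c3cccs3)cn2[C@@H]2O[C@H](CO)[C@@H](O)[C@H]2O)c(=O)[nH]1`: in this assay compound 2 gives > 20000 nM, again a limit.
Compound 3 `Cc1nc(N)c2c(-c3ccoc3)cn([C@@H]3O[C@H](CO)[C@@H](O)[C@H]3O)c2n1`: in this assay compound 3 gives > 20000 nM, also a limit.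

Compound 1 and compound 3 share one core and differ in a single place: furan-3-yl in place of thiophen-2-yl on an aromatic carbon. The step that the two limits leave unreadable from compound 1 to compound 3 cannot be sized, because both ends sit at a limit. Compound 2 carries a different core; the difference between the two cores is not broken down here.

Compound 4 `Nc1nc2c(c(-c3ccoc3)cn2[C@@H]2O[C@H](CO)[C@@H](O)[C@H]2O)c(=O)[nH]1` has not yet been measured. It stands to compound 2 as compound 3 stands to compound 1, the same change at the same place: furan-3-yl in place of thiophen-2-yl on an aromatic carbon. With only limits available, the change gives no readable effect in either pair. Compound 4 is expected to remain inactive, because the limit of > 20000 nM in this assay, at which 3 of the 3 values shown sit, describes every value recorded so far. The expected step, a step that the limit leaves unreadable from compound 2 to compound 4, is therefore essentially nil. Compound 4 is estimated at 40000 nM, with a plausible range from 15000 nM to 150000 nM, most likely reported only as a limit.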

Compound 4, half-maximal inhibitory concentration: 10700 nM
The estimate for compound 4 lay 3.7-fold (0.57 log units) above the measured number; the measured number lies below the stated range.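

In this assay, furan-3-yl in place of thiophen-2-yl on the core of compound 2 gives an at least 1.8-fold lower number from compound 2 to compound 4 (0.27 log units; that floor lies within the scatter), so the change is tied here to a measured number on this core, although the printed floor alone does not establish a real gain. For the compounds shown here, the same change on the core of compound 1 cannot be read, as both of its ends are limits of the assay, so nothing shows that the step carries from one core to the other, and only a single readable pair supports it. Measured numbers remain scarce in this series, which leaves little to set this result against: the limit of > 20000 nM in this assay, at which 3 of the 4 values shown sit.

The compounds shown leave open whether thiophen-3-yl, furan-2-yl or phenyl on the same aromatic carbon would give a measured number on either core. They also leave open what an aminomethyl group, a carboxylic acid or a longer alkyl chain would do at that place.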